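Ethyl in place of hydrogen on the oxygen of compound 3

The source may report more compounds than this note shows. Statements on the series, on what has been measured and on what is new or still open speak of the compounds shown alone.

Compound 3 `COc1cc(N)c(Cl)cc1NC(=O)C1CCN(Cc2ccc(O)cc2)CC1` was examined in a functional assay on the whole organism for antagonist activity, with Mus musculus as the target; on this read-out higher numbers stand for an effect only at larger amounts of compound and lower numbers for an effect already at smaller amounts; there compound 3 gives > 8 mg/kg, a limit of the assay rather than a number, sitting at the limit of > 8 mg/kg in this assay, at which 1 of the 3 values shown sits. Compound 1 `COc1cc(N)c(Cl)cc1NC(=O)C1CCN(Cc2ccc(OCc3ccccc3)cc2)CC1` gives > 4 mg/kg in this assay, also a limit. Compound 2 `COc1cc(N)c(Cl)cc1NC(=O)C1CCN(Cc2ccccc2F)CC1` likewise reaches only the limit of > 4 mg/kg. Both a step that the two limits leave unreadable from compound 1 to compound 3 and a step that the two limits leave unreadable from compound 2 to compound 3 run from one limit to another, so neither tells how far compound 3 actually lies beyond its own limit. Compound 4 `CCOc1ccc(CN2CCC(C(=O)Nc3cc(Cl)c(N)cc3OC)CC2)cc1` differs from compound 3 by ethyl in place of hydrogen on an oxygen on an aromatic ring. For the measured compounds named here, no measured step covers this change, so nothing beyond the scatter is expected for a number no higher from compound 3 to compound 4 (the limit leaves the size open). Compound 4 is therefore estimated at 8 mg/kg, between 3 mg/kg and 25 mg/kg, and most likely again only a limit.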

Compound 4, dose for half-maximal effect: 6.3 mg/kg
The estimate for compound 4 lay 1.3-fold (0.10 log units) above the measured number; the measured number falls inside the stated range.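

With ethyl in place of hydrogen on the oxygen, compound 4 is the only one of the four compounds shown to give a number rather than a limit in this assay. The change gives an at least 1.2-fold lower number from compound 3 to compound 4 (0.10 log units; that floor lies within the scatter), and its true size stays open because compound 3 is itself only a limit: the limit of > 8 mg/kg in this assay, at which 1 of the 4 values shown sits.

The steps to compound 4 from compound 1 and from compound 2 cannot be read. Going by these compounds, what a longer chain such as propyl, or a chain ending in an amine, would give on this oxygen remains open.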